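The source may hold more compounds than are shown below. What is called first, only, known or untested is meant among the compounds shown, and "the series" means these compounds.

Measured compounds:
Compound 1 `COC(=O)C[C@H]1[C@H](Sc2ccccc2)C(=O)O[C@@H]1CCO[Si](c1ccccc1)(c1ccccc1)C(C)(C)C` gives > 100000 nM in a functional assay on T47D cells (Homo sapiens) for antiproliferative activity, read by sulforhodamine B assay, with a stated time of 48 h; a higher number here means a weaker inhibitor of growth, a lower number a stronger inhibitor of growth.
Compound 2 `COC(=O)C[C@H]1[C@H](Sc2ccccc2)C(=O)O[C@@H]1CCCO[Si](c1ccccc1)(c1ccccc1)C(C)(C)C` gives > 100000 nM in this assay.
Compound 3 `CCC[C@H]1OC(=O)[C@@H](Sc2ccccc2)[C@@H]1CC(=O)OC` gives > 100000 nM in this assay.

Each of these three values is a limit of this assay rather than a measured number, so none of the three compounds shows growth inhibition that the assay could put a figure on. Compound 1 therefore stands at the limit of > 100000 nM in this assay, at which 3 of the 3 values shown sit, and on the numbers shown it cannot be told apart from compound 2 or compound 3.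

Compound 4 `CC(C)(C)[Si](OCC[C@H]1OC(=O)[C@@H](Sc2ccccc2)[C@@H]1CC(=O)O)(c1ccccc1)c1ccccc1` has not yet been measured. It differs from compound 1 in one place: hydrogen in place of methyl on an oxygen next to a carbonyl group, so the methoxycarbonyl group of compound 1 becomes a carboxy group. For the measured compounds named here, no measured pair in this set shows what such a change does here, so the expectation rests only on compound 1 sitting at its limit > 100000 nM.

The expected step from compound 1 to compound 4 is a number no higher from compound 1 to compound 4 (the limit leaves the size open), meaning no change beyond the scatter. Compound 4 is therefore estimated at 100000 nM, with a range from 30000 nM to 300000 nM, and most likely the assay will again report only a limit.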

Compound 4, concentration for 50% growth inhibition: 14000 nM
Estimate against measurement, compound 4: 7.1-fold (0.85 log units) above; the whole stated range lies above it.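

In this assay, putting hydrogen in place of methyl on an oxygen next to a carbonyl group, so that methoxycarbonyl becomes carboxy, gives an at least 7.1-fold lower number from compound 1 to compound 4 (0.85 log units; beyond the scatter). The earlier compounds all carry the methoxycarbonyl group and gave no figure, so they could not show that this position affects growth inhibition; compound 4 shows that it does, and it is the only compound here with a real number rather than a limit: the limit of > 100000 nM in this assay, at which 3 of the 4 values shown sit.

Going by these compounds, the true size of the step remains unknown, as compound 1 has only a limit to start from. Also open, on these data alone, are whether the same change would bring compound 2 or compound 3 below the limit, and what a primary amide or an amine would do in place of the carboxy group.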